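A Fluoro-for-Chloro Swap in a Level Series

The source may report more compounds than this note shows. Statements on the series, on what has been measured and on what is new or still open speak of the compounds shown alone.

In a functional assay (Platelet, plasma) for inhibition, with Homo sapiens as the target (on this read-out lower numbers stand for stronger inhibition and higher numbers for weaker inhibition), compound 1 (`N#Cc1cc2c(nc1N1CCC(C(=O)NS(=O)(=O)Cc3ccc(F)cc3F)CC1)COC2=O`) gives 5200 nM and compound 2 (`N#Cc1cc2c(nc1N1CCC(C(=O)NS(=O)(=O)c3ccc(Cl)s3)CC1)COC2=O`) gives 4470 nM against the shared core. Compound 3 (`N#Cc1cc2c(nc1N1CCC(C(=O)NS(=O)(=O)Cc3ccc(Cl)cc3)CC1)COC2=O`) gives 4420 nM and so stands level with both, within the scatter of each.

Compound 4 (`N#Cc1cc2c(nc1N1CCC(C(=O)NS(=O)(=O)Cc3ccc(F)cc3)CC1)COC2=O`) carries fluoro in place of chloro on an aromatic carbon, para to a large group (fluoro in place of chloro on an aromatic carbon). Among the compounds with values here, no measured step makes exactly this exchange. The closest is the move from 2,4-difluorophenyl to 4-chlorophenyl (a 1.2-fold lower number from compound 1 to compound 3 (0.07 log units; within the scatter)), which stays within the scatter. The larger exchanges of the sulfonyl substituent (a 1.2-fold lower number from compound 1 to compound 2 (0.07 log units; within the scatter) and a 1.0-fold lower number from compound 2 to compound 3 (0.00 log units; within the scatter)) stay within it as well. Nothing among these three compounds therefore points to a real shift, and no change beyond the scatter is expected in this assay here. The estimated step (a 1.1-fold higher number from compound 3 to compound 4 (0.04 log units; within the scatter)) is accordingly small and without a meaningful direction. Compound 4 is expected to read about 4800 nM with an estimated range from 2400 nM to 9500 nM on this measure.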

Compound 4, half-maximal inhibitory concentration: 3500 nM
For compound 4 the middle estimate is 1.4-fold (0.14 log units) above the measured one; low and high end bracket the measured number.
By their numbers in this assay, from the lowest: compounds 4, 3, 2 and 1 (each within the scatter of the next).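

In this assay, within the data shown here, a 1.3-fold lower number from compound 3 to compound 4 (0.10 log units; within the scatter) gives the first direct reading of fluoro in place of chloro on this aromatic carbon, para to a large group, and the exchange stays within the scatter. The two wider comparisons also stay within it: a 1.3-fold lower number from compound 2 to compound 4 (0.11 log units; within the scatter) replaces 5-chlorothiophen-2-yl with 4-fluorobenzyl, and a 1.5-fold lower number from compound 1 to compound 4 (0.17 log units; within the scatter) puts hydrogen in place of fluoro on an aromatic carbon. The data available offer no independent measurement that bears on this result.

With only chloro and fluoro shown at this position, the four compounds leave open whether a methoxy, trifluoromethyl or amine group there would move the number beyond the scatter. From the compounds shown here alone, it also remains open whether a carboxylic acid or a longer chain on the sulfonyl sulfur would do so.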